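The source may report more compounds than this note shows. Statements on the series, on what has been measured and on what is new or still open speak of the compounds shown alone.

Series read in a functional assay on K562 cells (Homo sapiens) for antiproliferative activity, read by MTT assay, with a stated time of 48 h; on this read-out lower numbers stand for stronger inhibition and higher numbers for weaker inhibition:
- compound 1 `COC(=O)CNC(=O)c1ccc(Oc2nc3ccccc3nc2NC(C)(C)C)cc1`: > 50000 nM, a limit of the assay
- compound 2 `COC(=O)[C@H](C)NC(=O)c1ccc(Oc2nc3ccccc3nc2NC(C)(C)C)cc1`: 42200 nM

Among the compounds with values here, compound 2 holds the only actual number in this assay so far, since the single other value is the limit recorded in the limit of > 50000 nM in this assay, at which 1 of the 2 values shown sits.

Compound 3 `COC(=O)[C@H](CC(C)C)NC(=O)c1ccc(Oc2nc3ccccc3nc2NC(C)(C)C)cc1` follows from compound 2 by isopropyl in place of hydrogen on a saturated chain carbon, two bonds along the chain from an amide-type nitrogen and a carbonyl carbon. Within the data shown here, one measured step bears on this change: an at least 1.1-fold lower number from compound 1 to compound 2 (0.07 log units; that floor lies within the scatter). That step adds methyl in place of hydrogen within the same side chain, and its size is known only as a floor. A larger group enters here, but the data give no step beyond the scatter to scale from. Only a small move towards a lower number is therefore expected, possibly none beyond the scatter. The expected step is a 1.4-fold lower number from compound 2 to compound 3 (0.15 log units; within the scatter). For compound 3 the estimated value is 30000 nM, with an expected range of 10000 nM to 50000 nM.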

Compound 3, half-maximal inhibitory concentration: > 50000 nM
Compound 3: no number, only a limit (the forecaster's own chance of this, stated with the estimate: 35%); middle value at least 1.6-fold (0.22 log units) away from the limit.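

In this assay, going from methyl to isobutyl at this saturated chain carbon gives no sign of a further drop in the number, and the size of the change is known only as a floor: an at least 1.1-fold higher number from compound 2 to compound 3 (0.07 log units; that floor lies within the scatter). Within the data shown here, compound 3 gives > 50000 nM, which is a limit of the assay, so compound 2 still holds the only actual number. The step between compound 1 and compound 3 cannot be read, and the values at this position now gather at a single limit: the limit of > 50000 nM in this assay, at which 2 of the 3 values shown sit.

As far as these compounds go, whether any side chain at this carbon moves the number beyond the scatter stays open, for instance one ending in an amine or a carboxylic acid. From the compounds shown here alone, how far compound 3 and compound 1 lie past the limit also stays open.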